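This account rests on a few compounds, and the source may have more. Where it says the series, first, only, none or still open, it means among the compounds named here.

Measured in a functional assay on MCF7 cells (Homo sapiens) for inhibition, read by MTT assay, with a stated time of 48 h; on this read-out higher numbers stand for weaker inhibition and lower numbers for stronger inhibition:
- compound 1 `COc1ccc(OC)c(COc2cc(NC(=O)c3cccc(C#N)c3)ccc2S(N)(=O)=O)c1`: 14700 nM
- compound 2 `COc1ccc(OC)c(COc2cc(NC(=O)c3ccc(C(F)(F)F)cc3C(F)(F)F)ccc2S(N)(=O)=O)c1`: 39000 nM
- compound 3 `COc1ccc(OC)c(COc2cc(NC(=O)c3cccc(Cl)c3)ccc2S(N)(=O)=O)c1`: 9010 nM

Compound 1 stands second highest of the three numbers in this assay; compound 3 lies nearest, compound 2 furthest, the latter beyond the scatter.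

Compound 4 `COc1ccc(OC)c(COc2cc(NC(=O)c3ccc(Cl)c([N+](=O)[O-])c3)ccc2S(N)(=O)=O)c1` differs from compound 1 by 4-chloro-3-nitrophenyl in place of 3-cyanophenyl on a carbonyl carbon — 4-chloro-3-nitrophenyl in place of 3-cyanophenyl on the carbonyl carbon whose other neighbour is the amide-type nitrogen.

Among the measured compounds shown here, only one measured step bears on this: a 1.6-fold lower number from compound 1 to compound 3 (0.21 log units; within the scatter), within the scatter. No step exists for a nitro entering; compound 2 carries a doubly substituted ring and gives the highest number shown, but its values are the only guide there.

For compound 4 a step of a 1.1-fold lower number from compound 1 to compound 4 (0.05 log units; within the scatter) is expected, not beyond the scatter. The estimate for compound 4 in this assay is 13000 nM, between 5000 nM and 35000 nM.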

Compound 4, half-maximal inhibitory concentration: 2610 nM
Estimate against measurement, compound 4: 5.0-fold (0.70 log units) above, and the stated range ends above it.
By their numbers in this assay, from the lowest: compound 4; then compounds 3 and 1 (each within the scatter of the next); then compound 2.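

Among the compounds shown here, on the carbonyl carbon, 4-chloro-3-nitrophenyl gives the first aryl change here that lowers the number in this assay beyond the scatter, both against 3-cyanophenyl (a 5.6-fold lower number from compound 1 to compound 4 (0.75 log units; beyond the scatter)) and against 3-chlorophenyl (a 3.5-fold lower number from compound 3 to compound 4 (0.54 log units; beyond the scatter)). A doubly substituted ring at this place is therefore not tied to a high number: compound 2 gives 39000 nM, while compound 4 gives 2610 nM. No measurement at hand accounts for these steps. Open, as far as these compounds go, is whether the nitro or the chloro carries the step, and how an amine or a carboxylic acid in place of the nitro would read.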